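Cyano-to-methyl swap on the benzyl group: cytotoxicity notes

A few compounds are considered here, and "the series" means these few. Any claim that something is new, unique, unknown or untested is made for them only; others in the source may bear on it.

All values below come from a toxicity assay on NIH3T3 cells (Mus musculus) for cytotoxicity, read by resazurin assay; a higher number here means that more compound is needed for the effect, a lower number that less compound is needed.

compound 1 `COC(=O)c1ccc(NCc2cncn2Cc2ccccc2C)cc1-c1ccccc1`: 10000 nM
compound 2 `COC(=O)c1ccc(NCc2cncn2Cc2ccccc2C#N)cc1-c1ccccc1`: 25000 nM
compound 3 `COC(=O)c1ccc(NCc2cncn2Cc2ccc(C#N)cc2)cc1-c1ccccc1`: only a limit of the assay, > 10000 nM

Three compounds share one core and differ only in the benzyl group. Between compound 2 and compound 1 the change is methyl in place of cyano on an aromatic carbon, and it gave a 2.5-fold lower number from compound 2 to compound 1 (0.40 log units; beyond the scatter). The cores of compound 2 and compound 3 differ by 4-cyanophenyl in place of 2-cyanophenyl on a saturated chain carbon bound to an aromatic nitrogen; the step that the limit leaves unreadable from compound 2 to compound 3 stays unreadable because compound 3 sits at the limit (the limit of > 10000 nM in this assay, at which 1 of the 3 values shown sits). For the same reason a number no lower from compound 1 to compound 3 (the limit leaves the size open) cannot be sized.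

Compound 4 `COC(=O)c1ccc(NCc2cncn2Cc2ccc(C)cc2)cc1-c1ccccc1` has not yet been run in this assay. It differs from compound 3 by methyl in place of cyano on an aromatic carbon. Going by the values given here, this is the same kind of change as the one from compound 2 to compound 1, but not the same: there the methyl enters ortho to a large group, here it enters para to a large group. The earlier change lowered the number modestly, as a 2.5-fold lower number from compound 2 to compound 1 (0.40 log units; beyond the scatter) shows, and compound 3 itself starts at a limit, so the starting point is open.

The expected result for compound 4 is 10000 nM, with the estimated range 4000 nM to 30000 nM. This estimate means a number no higher from compound 3 to compound 4 (the limit leaves the size open), resting on the direction of a 2.5-fold lower number from compound 2 to compound 1 (0.40 log units; beyond the scatter) and on compound 1 at 10000 nM as the nearest measured methyl analogue. Compound 3 sits at a limit of the assay, which leaves a real chance that compound 4 also returns only a limit.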

Compound 4, half-maximal effective concentration: 50000 nM
Estimate against measurement, compound 4: 5.0-fold (0.70 log units) below, and the stated range ends below it.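

In this assay, methyl in place of cyano cannot be followed from one core to the other, and the step between the 4-cyanobenzyl and 4-methylbenzyl compounds, like every other step that touches compound 3, cannot be read because compound 3 stands at a limit: the limit of > 10000 nM in this assay, at which 1 of the 4 values shown sits.

What can be read is limited to a 5.0-fold higher number from compound 1 to compound 4 (0.70 log units; beyond the scatter), which lies beyond the scatter, and a 2.0-fold higher number from compound 2 to compound 4 (0.30 log units; within the scatter), which lies within it. The lower number seen in a 2.5-fold lower number from compound 2 to compound 1 (0.40 log units; beyond the scatter) is therefore neither confirmed nor contradicted for the 4-substituted benzyl group, and that single pair gives no general rule for this change across the series.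

The compounds shown leave open the size and even the direction of the cyano-to-methyl change on the 4-substituted benzyl group, which would need a number for the 4-cyanobenzyl compound rather than a limit. They also leave open how a methoxy group or a chlorine on the benzyl ring, or a carboxylic acid in place of the methyl ester, would read in this assay.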